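The source may report more compounds than this note shows. Statements on the series, on what has been measured and on what is new or still open speak of the compounds shown alone.

In a functional assay on HeLa cells (Homo sapiens) for antiproliferative activity, read by CCK-8 assay, with a stated time of 72 h (a higher number here means a weaker inhibitor, a lower number a stronger inhibitor), two compounds with the shared core have been measured so far. Compound 1 `CCSc1ccc(-c2cncnc2-c2cc(OC)c(OC)c(OC)c2)cc1` gives 370 nM, while compound 2 `COc1cc(-c2ncncc2-c2ccc(OC(C)C)cc2)cc(OC)c1OC` gives 8360 nM, the higher of the two numbers and thus the weaker result. Among the compounds with values here, the only measured step, a 23-fold higher number from compound 1 to compound 2 (1.35 log units; beyond the scatter), is large and lies beyond the scatter; in it, isopropoxy replaces ethylsulfanyl on an aromatic carbon. Compound 3 `COc1cc(-c2ncncc2-c2ccc(B(O)O)cc2)cc(OC)c1OC` is still unmeasured, and its structure differs from that of compound 2 by one exchange: a group of 3 heavy atoms (1 boron, 2 oxygen; no ring) in place of a group of 4 heavy atoms (3 carbon, 1 oxygen; no ring), on an aromatic carbon. Within the data shown here, only the step to compound 2, a 23-fold higher number from compound 1 to compound 2 (1.35 log units; beyond the scatter), bears on this change, and it shows that an exchange on an aromatic carbon can shift the number widely. Among the measured compounds shown here, no measured compound carries the entering group, so a moderate fall in the number is expected, with much uncertainty. The value estimated for compound 3 is 1800 nM, with an expected range from 250 nM to 10000 nM. The expected change is a 4.6-fold lower number from compound 2 to compound 3 (0.67 log units; beyond the scatter).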

Compound 3, half-maximal inhibitory concentration: 4000 nM
Compound 3: middle estimate off by 2.2-fold (0.35 log units), on the low side, and the stated range covers the measured number.
By their numbers in this assay, from the lowest: compound 1; then compound 3; then compound 2.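

In this assay the aromatic carbon para to a large group now carries a third kind of group, and the boron-bearing group gives a lower number than isopropoxy, with a 2.1-fold lower number from compound 2 to compound 3 (0.32 log units; beyond the scatter) as a modest move. Against ethylsulfanyl the same group falls well short, with an 11-fold higher number from compound 1 to compound 3 (1.03 log units; beyond the scatter) as a large move, so ethylsulfanyl keeps the lowest number of the three compounds, and the place separates all three groups by more than the scatter. Nothing measured accounts for this order.

Going by these compounds, whether the hydrogen-bond donors of the boron-bearing group play any part remains open, and a carboxylic acid or an amine at this place would bear on that. Whether a longer sulfur chain such as propylsulfanyl would keep or lower the number of ethylsulfanyl also stays unanswered.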